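Hydroaryl replacement on the anilino ring of compound 2

A few compounds are considered here, and "the series" means these few. Any claim that something is new, unique, unknown or untested is made for them only; others in the source may bear on it.

Measured compounds:
compound 1 `CC(C)n1cnc2c(Nc3cccc(Cl)c3)nc(NCOCc3ccc(C(=O)Nc4ccccc4N)cc3)nc21`: 60.5%
compound 2 `Nc1ccccc1NC(=O)/C=C/c1ccc(Cn2cnc3c(Nc4cccc(Cl)c4)nc(Cl)nc32)cc1`: 49.3%

In a functional assay on HepG2 cells (Homo sapiens) for antiproliferative activity, read by CCK-8 assay, with a stated time of 72 h, tested at 8 uM (on this read-out lower numbers stand for a weaker effect and higher numbers for a stronger effect at the one concentration tested), compound 1 gives 60.5% and compound 2 gives 49.3%; compound 2 thus stands lowest of the two, the gap to compound 1 lying beyond the scatter. Among the compounds with values here, no single-point step between measured compounds is available, so the next change is judged from these two numbers only.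

Compound 3 `Nc1ccccc1NC(=O)/C=C/c1ccc(Cn2cnc3c(Nc4ccccc4)nc(Cl)nc32)cc1` differs from compound 2 by hydrogen in place of chloro on an aromatic carbon. Within the data shown here, with the chloro removed and no measured counterpart for this change, the expected step of a number 7.3 percentage points lower from compound 2 to compound 3 (within the scatter) is small, if any, and not confidently beyond the scatter, likely downward. Compound 3 is therefore estimated at 42%, within 26% to 58%.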

Compound 3, a percentage reported as inhibition, at one concentration (the size of the read-out at that concentration, not a potency): 41.9%
Estimate against measurement, compound 3: 0.1 percentage points above; low and high end bracket the measured number.
By their numbers in this assay, from the lowest: compounds 3 and 2 (each within the scatter of the next); then compound 1.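

In this assay, within the data shown here, this is the first single-point step: replacing 3-chlorophenyl with phenyl on the anilino nitrogen gives a number 7.4 percentage points lower from compound 2 to compound 3 (within the scatter) at this aromatic carbon. At this single concentration, the chloro is therefore not shown to be needed for the read-out of this scaffold. No measured property bears on this step.

The compounds shown leave open whether a fluoro, a methoxy or an amine on this aromatic carbon would give a step beyond the scatter. They also leave open whether removing the chloro from compound 1 would give a similar step.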